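A few compounds are considered here, and "the series" means these few. Any claim that something is new, unique, unknown or untested is made for them only; others in the source may bear on it.

Measured so far in a functional assay on B16 cells (Mus musculus), read by spectrophotometry, with a stated time of 3 days; a lower number here means a stronger inhibitor, a higher number a weaker inhibitor:
- compound 1, `CCNC(=S)N/N=C/c1cccc2ccccc12`: 1100 nM
- compound 2, `S=C(N/N=C/c1cccc2ccccc12)Nc1ccccc1`: 500 nM
- compound 3, `COc1ccccc1NC(=S)N/N=C/c1cccc2ccccc12`: 920 nM

All three share the same core and differ only in the group on the thiocarbonyl carbon. Compound 2 gives the lowest number of the three in this assay; its step to compound 3 lies within the scatter, so the two cannot be ranked against each other, while its step to compound 1 is beyond the scatter (a 2.2-fold lower number from compound 1 to compound 2 (0.34 log units; beyond the scatter)).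

Compound 4, `CN(C)C(=S)N/N=C/c1cccc2ccccc12`, has not yet been measured. It differs from compound 2 in one place: dimethylamino in place of anilino on a thiocarbonyl carbon. Among the measured compounds shown here, the measured step that bears most on this is the one from compound 1 to compound 2, a modest move in the stronger direction when phenyl replaced ethyl on the amide-type nitrogen. Going from compound 2 to compound 4 removes that phenyl and gives a small group again, so the most reasonable expectation is a move back the other way, of a size similar to the step from compound 1 to compound 2, and not a move beyond it.

Compound 4 is therefore expected to give about 1500 nM in this assay, with a plausible range from 600 nM to 4000 nM, which corresponds to an expected step of a 3.0-fold higher number from compound 2 to compound 4 (0.48 log units; beyond the scatter).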

Compound 4, half-maximal inhibitory concentration: 280 nM
Compound 4: the middle estimate sits 5.4-fold (0.73 log units) above what was measured, and the stated range ends above it.
By their numbers in this assay, from the lowest: compounds 4, 2, 3 and 1 (each within the scatter of the next, the first and the last beyond it).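

In this assay, compound 2 and compound 4 cannot be told apart (a 1.8-fold lower number from compound 2 to compound 4 (0.25 log units; within the scatter)), so on this thiocarbonyl carbon dimethylamino, with no ring and no hydrogen-bond donor, does as well as anilino, which has one of each. An aromatic ring here is therefore not needed for a number in this range, and a small group does not by itself give a high number: ethylamino and dimethylamino both lack a ring, yet they lie clearly apart (a 3.9-fold lower number from compound 1 to compound 4 (0.59 log units; beyond the scatter)). Across these four compounds the number does not simply follow the size of the group, and no available data explain the difference between ethylamino and dimethylamino.

The compounds shown leave open whether that difference depends on the second carbon on the nitrogen or on the missing nitrogen hydrogen, a question that methylamino or diethylamino would help to settle. They also leave open how a ring that contains this nitrogen, such as pyrrolidine or morpholine, would compare with the open dimethylamino group.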